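Phenyl added to the saturated ring of compound 2

The compounds below may be only part of what the source reports. "The series", "measured", "known", "first", "only" and "open" are said of these compounds alone.

Measured in a functional assay on HEp-2 cells (Homo sapiens) for antiproliferative activity, read by MTT assay, with a stated time of 72 h; a lower number here means a stronger inhibitor, a higher number a weaker inhibitor (values below)
compound 1 (`O=c1c(Sc2nc3ccccc3[nH]2)coc2ccccc12`) gives 42600 nM
compound 2 (`CN1CCN(/C=C2\Oc3ccccc3C2=O)CC1`) gives > 50000 nM (a limit)

Compound 2 stands at > 50000 nM (a limit of the assay, not a number). Compound 3 (`CN1CCN(/C=C2\Oc3ccccc3C2=O)C(c2ccccc2)C1`) differs from it in one place: phenyl in place of hydrogen on a saturated ring carbon. Going by the values given here, no measured step covers this change, so at most a modest gain is expected, possibly none beyond the scatter. In this assay the expected change is an at least 1.2-fold lower number from compound 2 to compound 3 (0.09 log units; that floor lies within the scatter) (estimated, towards a stronger inhibitor). For compound 3 the expected value is 40000 nM (estimated range 15000 nM to 80000 nM).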

Compound 3, half-maximal inhibitory concentration: > 50000 nM
Compound 3: a limit, no number; the forecaster's own chance of this, stated with the estimate: 45%; middle value at least 1.2-fold (0.09 log units) away from the limit.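

Compound 2 and compound 3 both stand as limits of the assay, not numbers, so no step can be read between them: the limit of > 50000 nM in this assay, at which 2 of the 3 values shown sit.

As far as these compounds go, whether phenyl in place of hydrogen on a saturated ring carbon changes antiproliferative activity at all stays open.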